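Hydroxy for Fluoro on a Weak Whole-Plant Inhibitor

The source may report more compounds than this note shows. Statements on the series, on what has been measured and on what is new or still open speak of the compounds shown alone.

Compound 1, `Cc1nc(Nc2ccc(F)cc2)c2cc[nH]c2n1`: 372000000 nM
Compound 2, `CCc1ccc(Nc2[nH]c(C)nc3nccc2-3)cc1`: 214000000 nM

Of the compounds shown here, two sharing the same core have been measured in a functional assay on the whole organism for inhibition, with Nicotiana tabacum as the target; a higher number here means a weaker inhibitor, a lower number a stronger inhibitor. In this assay compound 1 gives 372000000 nM, the higher of the two numbers. In this assay compound 2 gives 214000000 nM. The gap between compound 1 and compound 2 lies within the usual scatter of this assay, so the two numbers show no difference in inhibition that can be relied upon, and neither compound can be called the weaker of the pair.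

The account now follows compound 1 to compound 3, `Cc1nc(Nc2ccc(O)cc2)c2cc[nH]c2n1`. The change is hydroxy in place of fluoro on an aromatic carbon. Going by the values given here, no pair among the measured compounds shows a change of this kind, so there is no measured step to lean on. On the two numbers available, the expected step in this assay from the hydroxy for fluoro exchange is none beyond the scatter, and the estimated step is a 1.2-fold lower number from compound 1 to compound 3 (0.07 log units; within the scatter). Compound 3 is therefore expected to give about 320000000 nM in this assay, with an estimated range from 100000000 nM to 1000000000 nM.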

Compound 3, half-maximal inhibitory concentration: 155000000 nM
Beside the measured number, compound 3's estimate is 2.1-fold (0.31 log units) above it; the range from low to high includes it.
By their numbers in this assay, from the lowest: compounds 3, 2 and 1 (each within the scatter of the next, the first and the last beyond it).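

Hydroxy in place of fluoro on an aromatic carbon, para to a large group, gives in this assay a 2.4-fold lower number from compound 1 to compound 3 (0.38 log units; beyond the scatter), a modest step but the only one here that exceeds the scatter and isolates a change in one place. Going by these compounds alone, compounds 1 and 2 could not show this, as their numbers lie within the scatter of each other and no measured step connected them, whereas this result shows that the number in this assay does respond to the group on this carbon. The exchange adds one hydrogen-bond donor and one hydrogen-bond acceptor to the count, but nothing measured here links the step to any property of either group.

This single step leaves open whether an amine, a methoxy group or a carboxylic acid on the same carbon would lower the number further, leave it within the scatter or raise it. It also leaves open whether hydroxy in place of fluoro would give a similar step on another carbon of the ring or on a compound with an ethyl group elsewhere in the series.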